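The source may hold more compounds than are shown below. What is called first, only, known or untested is meant among the compounds shown, and "the series" means these compounds.

Measured in an ADME assay on HOS cells (Homo sapiens) for cytotoxicity (on this read-out lower numbers stand for higher toxicity in this test and higher numbers for lower toxicity in this test), so far:
- compound 1 `CN1CCC[C@H](Cn2c(CN(C)[C@H]3CCCc4cccnc43)nc3ccccc32)C1` gives 3600 nM
- compound 2 `CN1CCC[C@H](Cn2c(CN(C)[C@@H]3CCCc4cccnc43)nc3ccccc32)C1` gives 3600 nM

Within the data shown here, compound 1 stands level with compound 2, the only other measured compound. Between them the data show no change at the digits printed from compound 1 to compound 2 (within the scatter). Among the measured compounds shown here, that step goes with the fact that compounds 1 and 2 differ only in the configuration as drawn and is the only measured step.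

Compound 3 `CC(C)CN1CCC[C@H](Cn2c(CN(C)[C@H]3CCCc4cccnc43)nc3ccccc32)C1` keeps the core and the configuration of compound 1 and carries one new feature, (isopropyl in place of hydrogen on a saturated chain carbon bound to an amine nitrogen in a ring). The same change reads methyl to isobutyl, on the amine nitrogen in the ring. The measured step of no change at the digits printed from compound 1 to compound 2 (within the scatter) concerns configuration at a different stereocentre, so it bears on this change only indirectly. For the measured compounds named here, no measured compound varies the group on that nitrogen. With no evidence for a direction, no step beyond the scatter is expected, though the uncertainty is wide. The estimated change is a 1.2-fold lower number from compound 1 to compound 3 (0.08 log units; within the scatter) in this assay. For compound 3 the expected value is 3000 nM, with an estimated range from 1200 nM to 7500 nM as its bounds.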

Compound 3, half-maximal cytotoxic concentration: > 2000 nM
Compound 3 ended at the assay's limit; the forecaster's own chance of this, stated with the estimate: 10%; the middle value is on the limit's open side.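

In this assay compound 3 gives > 2000 nM, which is a limit of the assay and not a number. Among these compounds, no step from compound 1 to compound 3 can therefore be read. The compounds shown leave open whether going from 1-methylpiperidin-3-yl to 1-isobutylpiperidin-3-yl changes the half-maximal cytotoxic concentration at all, and in which direction.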